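Benzyl in place of 1H-benzimidazol-2-yl at the sulfur carbon

This account rests on a few compounds, and the source may have more. Where it says the series, first, only, none or still open, it means among the compounds named here.

Compound 1 `Cc1cc(Nc2cc(-c3ccccc3)[nH]n2)n2nc(SCc3c(Cl)cccc3Cl)nc2n1`: 3230 nM
Compound 2 `Cc1cc(Nc2cc(-c3ccccc3)[nH]n2)n2nc(SCc3nc4ccccc4[nH]3)nc2n1`: 2730 nM

In a functional assay on MCF7 cells (Homo sapiens) for inhibition, read by MTT assay, with a stated time of 72 h (a lower number here means a stronger inhibitor, a higher number a weaker inhibitor), compound 2 gives 2730 nM and compound 1 gives 3230 nM, the two numbers lying within the scatter of each other, as the step of a 1.2-fold lower number from compound 1 to compound 2 (0.07 log units; within the scatter) shows. Compound 3 `Cc1cc(Nc2cc(-c3ccccc3)[nH]n2)n2nc(SCCc3ccccc3)nc2n1` carries the change (benzyl in place of 1H-benzimidazol-2-yl on a saturated chain carbon bound to a sulfur). Among the compounds with values here, the one known step exchanged the group on that same saturated chain carbon for one of very different make-up and moved the number little, so this further exchange is expected to leave the number nearly where it stands, with a step of a 1.3-fold higher number from compound 2 to compound 3 (0.11 log units; within the scatter) expected. The estimate for compound 3 is 3500 nM, within 1400 nM to 9000 nM.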

Compound 3, half-maximal inhibitory concentration: 2700 nM
The estimate for compound 3 lay 1.3-fold (0.11 log units) above the measured number; measured number inside the range.
By their numbers in this assay, from the lowest: compounds 3, 2 and 1 (each within the scatter of the next).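

In this assay, benzyl in place of 1H-benzimidazol-2-yl on the saturated chain carbon bound to a sulfur gives a 1.0-fold lower number from compound 2 to compound 3 (0.00 log units; within the scatter), and benzyl in place of 2,6-dichlorophenyl gives a 1.2-fold lower number from compound 1 to compound 3 (0.08 log units; within the scatter). The position thus holds a group with no hydrogen-bond donor or acceptor as well as one with one of each, and all three numbers lie within the scatter of each other. No measured evidence accounts for this. Open, on these data alone, is whether an amine, a carboxylic acid or a longer chain at this carbon would also stay within that scatter.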